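A few compounds are considered here, and "the series" means these few. Any claim that something is new, unique, unknown or untested is made for them only; others in the source may bear on it.

In an ADME assay on HOS cells (Homo sapiens) for cytotoxicity, read by luminescence and ATP content, with a stated time of 48 h (a lower number here means that less compound is tolerated, a higher number that more compound is tolerated), compound 1 (`Nc1c(C(=O)NCc2ccc(F)cc2F)c(=O)n(O)c2ncc(CCCOCCO)cc12`) gives > 250000 nM, a limit of the assay and not a number. Compound 2 (`Nc1c(C(=O)NCc2ccc(F)cc2F)c(=O)n(O)c2ncc(CCC(=O)NCCO)cc12`) gives > 250000 nM, which is also a limit, so it has no exact place on the scale. Both compounds sit at the same ceiling: the limit of > 250000 nM in this assay, at which 2 of the 2 values shown sit. Within the data shown here, the only measured step is a step that the two limits leave unreadable from compound 1 to compound 2, and it offers no size to carry forward.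

Compound 3 (`COC(=O)CCc1cnc2c(c1)c(N)c(C(=O)NCc1ccc(F)cc1F)c(=O)n2O`) carries a change at a new place: methoxy in place of (2-hydroxyethyl)amino on a carbonyl carbon. Methoxy stands in place of (2-hydroxyethyl)amino on a carbonyl carbon, so 2-((2-hydroxyethyl)carbamoyl)ethyl becomes 2-(methoxycarbonyl)ethyl. Among the measured compounds shown here, no measured step covers this exchange, and the data give no size for it. The expectation therefore rests on compound 2 and its reading of > 250000 nM. In this assay a result near that limit is expected, with a modest move towards less compound tolerated as the only direction left open. For compound 3 the estimate is 180000 nM, with an expected range from 50000 nM to 250000 nM. This estimate means an expected at least 1.3-fold lower number from compound 2 to compound 3 (0.14 log units; that floor lies within the scatter).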

Compound 3, half-maximal cytotoxic concentration: > 250000 nM
Compound 3: a limit, no number; the forecaster's own chance of this, stated with the estimate: 55%; middle value at least 1.3-fold (0.14 log units) from the limit.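

In this assay compound 3 gives > 250000 nM, again a limit of the assay and not a number. Among these compounds, no step among compound 1, compound 2 and compound 3 can be read, because all three stand at the same ceiling: the limit of > 250000 nM in this assay, at which 3 of the 3 values shown sit. The compounds shown leave open where the half-maximal cytotoxic concentration of each lies, and so whether these exchanges shift it at all.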